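Compound 2 at the Bottom, and a Swap on Its Carbonyl

The compounds below may be only part of what the source reports. "The series", "measured", "known", "first", "only" and "open" are said of these compounds alone.

Measured so far in an ADME assay on a cell-free system (plasma, Mus musculus, strain CD-1) for metabolic stability, read by LC-MS, with a stated time of 2 h, tested at 1 ug/mL; on this read-out higher numbers stand for a more stable compound and lower numbers for a less stable compound:
- compound 1 `CC(C)OC(=O)c1ccc(N)cc1O`: 94%
- compound 2 `CC(C)OC(=O)OCOC(=O)c1ccc(N)cc1O`: 0%
- compound 3 `CNc1ccc(C(=O)OC)c(O)c1`: 90%

Among these three, compound 2 stands lowest, at 0%. Compound 3, at 90%, and compound 1, at 94%, both lie far above it, well beyond the scatter of repeated measurements.

The next compound in the account is compound 4 `CC(C)(C)C(=O)OCOC(=O)c1ccc(N)cc1O`, which has not yet been measured. It departs from compound 2 in one place, with tert-butyl in place of isopropoxy on a carbonyl carbon. The rest of the structure is shared. Going by the values given here, no measured pair of compounds differs in a single place, and no measured compound carries this tert-butyl group, so the expectation rests on compound 2 alone.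

Since compound 2 reads 0%, a change in this assay could only go upward. The expected outcome is a small rise that stays within the scatter, though a modest real gain cannot be excluded. In numbers, the estimate is a number 5 percentage points higher from compound 2 to compound 4 (within the scatter). For compound 4 the expected value in this assay is 5%, with an estimated range from 0% to 30%.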

Compound 4, percent of the compound remaining: 0%
For compound 4 the middle estimate is 5 percentage points above the measured one, within the range that was stated.
By their numbers in this assay, from the lowest: compounds 2 and 4 (each within the scatter of the next); then compounds 3 and 1 (each within the scatter of the next).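

In this assay, going by these compounds alone, tert-butyl in place of isopropoxy on a carbonyl carbon gives no change at the digits printed from compound 2 to compound 4 (within the scatter), the first single-place step. The reading at the bottom of the scale is therefore not tied to isopropoxy alone: it persists when this group gives way to tert-butyl, which carries no oxygen, while the rest of the structure stays the same, although a reading this low could not register any further loss. Nothing available here explains why the reading does not change at this position.

Within the data shown here, still open is whether any other group on this carbonyl carbon, such as an amine or a longer chain, would give a reading above that of compound 2 in this assay, since tert-butyl and isopropoxy are the only two groups seen there. Also open, on these data alone, is whether compound 2 and compound 4 differ in how quickly they are lost, which a single reading at the end of the incubation cannot tell when both stand at the bottom of the scale.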